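This account rests on a few compounds, and the source may have more. Where it says the series, first, only, none or still open, it means among the compounds named here.

Measured compounds in an assay for binding affinity to Alpha-1A adrenergic receptor (Homo sapiens); on this read-out higher numbers stand for weaker inhibition and lower numbers for stronger inhibition:
compound 1 `CN1CCCCC(n2nc(Cc3ccc(Cl)cc3)c3ccccc3c2=O)C1` — 158 nM
compound 2 `CN1CCCC1CCn1nc(Cc2ccc(Cl)cc2)c2ccccc2c1=O` — 316 nM
compound 3 `CN(C)CCCn1nc(Cc2ccc(Cl)cc2)c2ccccc2c1=O` — 316 nM

Compound 3 stands level with compound 2 at the digits given, and these two carry the highest of the three numbers; the step of no change at the digits printed from compound 2 to compound 3 (within the scatter) is within the scatter. Against compound 1 the step of a 2.0-fold higher number from compound 1 to compound 3 (0.30 log units; within the scatter) is likewise within the scatter, as is a 2.0-fold higher number from compound 1 to compound 2 (0.30 log units; within the scatter), so no measured step in the series moves this assay beyond its usual spread.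

Compound 4 `CN1CCC(n2nc(Cc3ccc(Cl)cc3)c3ccccc3c2=O)CC1` is the next member. Its change relative to compound 3 is 1-methylpiperidin-4-yl in place of 3-(dimethylamino)propyl on an aromatic nitrogen. The amine-bearing ring is thus joined directly to the aromatic nitrogen, as it is in compound 1, whereas in compound 3 the amine sits at the end of a chain. Among the compounds with values here, the steps that bear on this are a 2.0-fold higher number from compound 1 to compound 3 (0.30 log units; within the scatter) and a 2.0-fold higher number from compound 1 to compound 2 (0.30 log units; within the scatter), both small, and neither exceeds the scatter. A step of no more than that size is therefore expected, and the estimated step is a 1.4-fold lower number from compound 3 to compound 4 (0.16 log units; within the scatter). Any lean toward a lower number rests only on compound 1, which gives 158 nM in this assay. Compound 4 is expected at 220 nM, with a range from 70 nM to 700 nM.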

Compound 4, inhibition constant: 15.9 nM
Estimate against measurement, compound 4: 14-fold (1.14 log units) above; measured number below the stated range.
By their numbers in this assay, from the lowest: compound 4; then compounds 1, 2 and 3 (each within the scatter of the next).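

Within the data shown here, until now this position on the aromatic nitrogen had produced only steps within the scatter in this assay, but 1-methylpiperidin-4-yl is the first group there to give a large change, both against the chain of compound 3 (a 20-fold lower number from compound 3 to compound 4 (1.30 log units; beyond the scatter)) and against the chain of compound 2 (a 20-fold lower number from compound 2 to compound 4 (1.30 log units; beyond the scatter)). A ring joined directly to the aromatic nitrogen is not enough to give this result, as compound 1 also has that arrangement and the change to the six-membered ring still gives a clear step (a 9.9-fold lower number from compound 1 to compound 4 (1.00 log units; beyond the scatter)), so among the compounds shown, the identity of the ring matters as well as the removal of the chain. No measurement here bears on what lies behind these steps.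

The compounds shown leave open whether the low number persists with a 1-methylpiperidin-3-yl group, a 1-methylpyrrolidin-3-yl group or a piperidin-4-yl group carrying hydrogen instead of methyl on its ring nitrogen. They also leave open whether the step to 1-methylpiperidin-4-yl holds when the 4-chlorobenzyl group is replaced by an unsubstituted benzyl group.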